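A few compounds are considered here, and "the series" means these few. Any claim that something is new, unique, unknown or untested is made for them only; others in the source may bear on it.

Measured in a functional assay on DU-145 cells (Homo sapiens) for cytotoxicity, read by MTT assay; a lower number here means a stronger inhibitor, a higher number a weaker inhibitor:
- Compound 1 `CCCC(O)CC(=O)O[C@H](CC=C(C)C)C1=CC(=O)c2c(O)ccc(O)c2C1=O`: > 100000 nM
- Compound 2 `CC(=O)OCCO[C@H](CC=C(C)C)C1=CC(=O)c2c(O)ccc(O)c2C1=O`: 15500 nM

The entry for compound 1, > 100000 nM, is a limit. For the measured compounds named here, compound 2, at 15500 nM, therefore holds the only exact number so far. Compound 3 `COCCO[C@H](CC=C(C)C)C1=CC(=O)c2c(O)ccc(O)c2C1=O` has methyl in place of acetyl on an oxygen on a saturated carbon. One measured step is available, an at least 6.4-fold lower number from compound 1 to compound 2 (0.80 log units; beyond the scatter), but it is a different change and rests on a limit, (the limit of > 100000 nM in this assay, at which 1 of the 2 values shown sits), so it sets no direction here. In this assay, the expected change is none beyond the scatter, an estimated 1.2-fold higher number from compound 2 to compound 3 (0.06 log units; within the scatter). Compound 3 is expected at 18000 nM, within an estimated range of 6000 nM to 55000 nM.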

Compound 3, half-maximal inhibitory concentration: 43200 nM
Estimate against measurement, compound 3: 2.4-fold (0.38 log units) below, within the range that was stated.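

In this assay, the group on this oxygen on a saturated carbon matters even within the 2-substituted ethyl series, as acetyl to methyl gives a 2.8-fold higher number from compound 2 to compound 3 (0.45 log units; beyond the scatter). The number therefore moves with this small change, and acetyl gives the lower number of the two. Compound 1 carries a limit, and an at least 2.3-fold lower number from compound 1 to compound 3 (0.36 log units; beyond the scatter) is only a bound: the limit of > 100000 nM in this assay, at which 1 of the 3 values shown sits.

The compounds shown leave open how a free hydroxyl, a benzoyl or a longer chain on this oxygen would compare with acetyl and methyl. They also do not show why acetyl and methyl differ.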